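The compounds below may be only part of what the source reports. "The series", "measured", "known", "first", "only" and "open" are said of these compounds alone.

Measured so far:
- compound 1, `COc1cc(-c2cc(C=O)cc3cc(OC)c(O)cc23)ccc1O`: 500 nM
- compound 2, `COc1cc(-c2cc(C=O)cc3ccc(O)c(OC)c23)ccc1O`: 200 nM
- compound 3, `COc1cc(-c2c(O)c(C=O)cc3cc(OC)c(O)cc23)ccc1O`: 110 nM

These three compounds were tested in a functional assay on RAW264.7 cells (Mus musculus) for inhibition, read by Griess assay, with a stated time of 24 h; on this read-out lower numbers stand for stronger inhibition and higher numbers for weaker inhibition. Among them compound 1 carries the highest number, and so the weakest inhibition: compound 2 sits a step below it, and compound 3 sits furthest below. Going by the values given here, the one single-point step that has been measured runs from compound 1 to compound 3, where a hydroxy replaces a hydrogen on an aromatic carbon of the shared core, and it gives a 4.5-fold lower number from compound 1 to compound 3 (0.66 log units; beyond the scatter).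

Compound 4, `COc1cc(-c2cc(C=O)c(O)c3cc(OC)c(O)cc23)ccc1O`, has not yet been measured in this assay. It differs from compound 1 by hydroxy in place of hydrogen on an aromatic carbon. Among the compounds with values here, this is the same kind of change as the one leading to compound 3, a hydroxy entering on an aromatic carbon of the same core, but on a different aromatic carbon, ortho to a formyl group and ortho to a fused ring. The measured step therefore bears on it, though not exactly, since the hydroxy in compound 3 sits elsewhere.

On this basis compound 4 is expected to give a lower number than compound 1, with a step that is estimated at a 2.3-fold lower number from compound 1 to compound 4 (0.36 log units; beyond the scatter), kept somewhat short because a 4.5-fold lower number from compound 1 to compound 3 (0.66 log units; beyond the scatter) was measured with the hydroxy at a different place on the core. Compound 4 is thus estimated at 220 nM, with a likely range from 90 nM to 550 nM.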

Compound 4, half-maximal inhibitory concentration: 150 nM
The estimate for compound 4 lay 1.5-fold (0.17 log units) above the measured number; the range from low to high includes it.
By their numbers in this assay, from the lowest: compounds 3, 4 and 2 (each within the scatter of the next); then compound 1.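

In this assay, hydroxy in place of hydrogen on the aromatic carbon ortho to a formyl group and ortho to a fused ring gives a 3.3-fold lower number from compound 1 to compound 4 (0.52 log units; beyond the scatter) and lies beyond the scatter. The lower number that came with this change is thus no longer tied to a single carbon of the shared core, as a 4.5-fold lower number from compound 1 to compound 3 (0.66 log units; beyond the scatter) is now joined by a second step of the same kind at a different place. Nothing measured here explains why a hydroxy on this carbon goes with a lower number.

The compounds shown leave open whether an amine, a carboxylic acid or a longer chain such as propoxy on this same carbon would also give a lower number than the hydrogen of compound 1. They also leave open what hydroxy on both of these carbons at once would give, and whether the same change would lower the number on the core of compound 2.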